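Ester variation in a dihydropyridine series: compound 3

A few compounds are considered here, and "the series" means these few. Any claim that something is new, unique, unknown or untested is made for them only; others in the source may bear on it.

Two esters of the shared core have been measured. Compound 1 `COC(=O)C1=C(C)NC(C)=C(C(=O)OCCCl)C1c1cccc([N+](=O)[O-])c1` carries a chloroethyl ester and in a functional assay on HEK293 cells for antagonist activity at Voltage-dependent L-type calcium channel subunit alpha-1C (Oryctolagus cuniculus), read by FLIPR (a lower number here means a stronger inhibitor, a higher number a weaker inhibitor), compound 1 gives 26 nM. Compound 2 `COC(=O)C1=C(C)NC(C)=C(C(=O)OCc2ccc(OC)c(OC)c2)C1c1cccc([N+](=O)[O-])c1` carries the 3,4-dimethoxybenzyl ester instead, and in this assay compound 2 gives 112 nM. For the measured compounds named here, the single step between them, a 4.3-fold higher number from compound 1 to compound 2 (0.63 log units; beyond the scatter), is the only measured step in the set; compound 2 therefore stands with the higher of the two numbers, and compound 1 is its only neighbour.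

Compound 3 `COC(=O)C1=C(C)NC(C)=C(C(=O)OCCCCc2ccc(OC)cc2)C1c1cccc([N+](=O)[O-])c1` is the next ester: 3-(4-methoxyphenyl)propyl in place of 3,4-dimethoxyphenyl on a saturated chain carbon bound to an oxygen next to a carbonyl group. The change keeps one methoxy-bearing aromatic ring and lengthens the saturated chain between that ring and the ester oxygen. The measured step from compound 1 to compound 2 shows that moving from a small ester substituent to an aromatic one weakens inhibition modestly; it does not tell how one aromatic ester compares with another. Going by the values given here, with no step of that kind available, the expectation for compound 3 is a step of a 1.0-fold lower number from compound 2 to compound 3 (0.01 log units; within the scatter), that is, no change beyond the scatter. The estimate for compound 3 in this assay is 110 nM, within 40 nM to 320 nM.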

Compound 3, half-maximal inhibitory concentration: 17 nM
Compound 3: the middle estimate sits 6.5-fold (0.81 log units) above what was measured; the whole stated range lies above it.
By their numbers in this assay, from the lowest: compounds 3 and 1 (each within the scatter of the next); then compound 2.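

In this assay the two aromatic esters are separated by a 6.6-fold lower number from compound 2 to compound 3 (0.82 log units; beyond the scatter), so at this position an aromatic ring does not by itself fix the number; what surrounds the ring matters. Compound 2 no longer stands for aromatic esters as a class: a 1.5-fold lower number from compound 1 to compound 3 (0.18 log units; within the scatter) lies within the scatter, so the 3-(4-methoxyphenyl)propyl ester and the chloroethyl ester cannot be told apart here, and the weakening seen with the 3,4-dimethoxybenzyl ester does not carry over to compound 3. No measurement shown offers a reason for either step.

The change from compound 2 to compound 3 alters the saturated chain and the methoxy substitution on the ring together, and the compounds shown do not separate the two. As far as these compounds go, whether a 3-(3,4-dimethoxyphenyl)propyl ester or an unsubstituted 3-phenylpropyl ester would sit with compound 2 or with compound 3 remains open, as does the result of a longer chain or a terminal amine on the same ester.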